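Cell Tolerance From Compound 1 to Compound 4

The compounds below may be only part of what the source reports. "The series", "measured", "known", "first", "only" and "open" are said of these compounds alone.

Measured compounds and their values:
- Compound 1 `CC(C)[C@H](NC(=O)[C@]1(Cc2ccccc2)CCN1C(=O)OCc1ccccc1)C(N)=O`: in an ADME assay on HELF cells (Homo sapiens) for cytotoxicity, with a stated time of 3 days (a higher number here means that more compound is tolerated, a lower number that less compound is tolerated), compound 1 reaches the limit > 100000 nM
- Compound 2 `C[C@H](NC(=O)[C@]1(Cc2ccccc2)CCN1C(=O)Oc1cccc2ccccc12)C(N)=O`: in this assay compound 2 reaches the limit > 100000 nM
- Compound 3 `C[C@H](NC(=O)[C@]1(Cc2ccccc2)CCN1S(=O)(=O)c1ccc2ccccc2c1)C(N)=O`: in this assay compound 3 reaches the limit > 100000 nM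

Compound 1 therefore stands at the upper edge of what this assay can report, and only a limit, not a number, is known for it. The same holds for compounds 2 and 3, so nothing separates the three: the limit of > 100000 nM in this assay, at which 3 of the 3 values shown sit. Going by the values given here, no compound in this set has yet given a numeric reading, and no step between two measured compounds can be drawn.

Compound 4 `C[C@H](NC(=O)[C@]1(Cc2ccccc2)CCN1C(=O)OCc1ccccc1)C(=O)NC(C)(C)C` has not been measured. It differs from compound 1 in one place: 1-((tert-butyl)carbamoyl)ethyl in place of 1-carbamoyl-2-methylpropyl on an amide-type nitrogen. Among the compounds with values here, since every value so far sits at the limit, the outcome for compound 4 is expected to be no change beyond the scatter in this assay, that is, a step of a number no higher from compound 1 to compound 4 (the limit leaves the size open). Compound 4 is accordingly expected to give 100000 nM, with a range from 50000 nM to 200000 nM, and most probably to return only the same limit.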

Compound 4, minimum cytotoxic concentration: > 100000 nM
Compound 4 ended at the assay's limit; the forecaster's own chance of this, stated with the estimate: 85%; the middle value lies on the limit itself.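

Compound 1 and compound 4 both return only a limit, so no step between them can be read: the limit of > 100000 nM in this assay, at which 4 of the 4 values shown sit.

The compounds shown leave open what numeric reading any of them would give in this assay, and whether 1-((tert-butyl)carbamoyl)ethyl in place of 1-carbamoyl-2-methylpropyl changes how well the compound is tolerated.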